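Ring size at the ester oxygen in a furan series

A few compounds are considered here, and "the series" means these few. Any claim that something is new, unique, unknown or untested is made for them only; others in the source may bear on it.

Compound 3 `CC1=C(C(=O)OC2CCC2)C(c2ccco2)NC(=O)N1` gives 1% in an assay on membranes from HeLa cells for displacement of a labelled ligand from adenosine receptor A3 (Homo sapiens), read by scintillation counting, with a stated time of 180 min, tested at 1 uM (on this read-out lower numbers stand for less inhibition and higher numbers for more inhibition at the one concentration tested (going by the name of the read-out)), level with compound 1 `CCCC(=O)C1=C(C)NC(=O)NC1c1ccco1` at 1%, while compound 2 `CCC(C)OC(=O)C1=C(C)NC(=O)NC1c1ccco1` gives 3%; all three numbers sit close together. Compound 4 `CC1=C(C(=O)OC2CCCCC2)C(c2ccco2)NC(=O)N1` differs from compound 3 in one place: cyclohexyl in place of cyclobutyl on an oxygen next to a carbonyl group. The measured step that bears most directly on this is the swap of one ester group for another, a number 2 percentage points lower from compound 2 to compound 3 (within the scatter); the steps of a number 2 percentage points higher from compound 1 to compound 2 (within the scatter) and no change at the digits printed from compound 1 to compound 3 (within the scatter) also stay within the scatter. Within the data shown here, each change at that position so far has left the read-out flat, so no step beyond the scatter is expected in this assay here. Compound 4 is therefore estimated at 2%, between 0% and 12%, an expected step of a number 1 percentage points higher from compound 3 to compound 4 (within the scatter).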

Compound 4, a percentage reported as inhibition, at one concentration (the size of the read-out at that concentration, not a potency): 4%
For compound 4 the middle estimate is 2 percentage points below the measured one, and the stated range covers the measured number.
By their numbers in this assay, from the lowest: compounds 1, 3, 2 and 4 (each within the scatter of the next).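

A ring of six carbons on the ester oxygen reads no differently from the smaller groups in this assay: cyclohexyl against cyclobutyl gives a number 3 percentage points higher from compound 3 to compound 4 (within the scatter), and against sec-butyl it gives a number 1 percentage points higher from compound 2 to compound 4 (within the scatter). Cyclohexyloxy in place of propyl on the carbonyl carbon gives a number 3 percentage points higher from compound 1 to compound 4 (within the scatter), so all four compounds remain close together, and this position has shown no sensitivity to ring size so far. Nothing available offers an explanation for this flat result.

From the compounds shown here alone, whether an ester carrying an amine or a carboxylic acid, or a benzyl ester, would move this read-out remains open.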